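Solubility notes: aminomethyl for methylcarbamoyl on the shared core

The source may report more compounds than this note shows. Statements on the series, on what has been measured and on what is new or still open speak of the compounds shown alone.

Among the measured compounds shown here, compound 2 `CNC(=O)c1cccc(-c2cnc(Nc3ccc(F)cc3)o2)c1` gives 3100 nM in a physicochemical assay for solubility, using the shake flask method, measured as kinetic solubility, at pH 7.4 (on this read-out lower numbers stand for lower solubility and higher numbers for higher solubility), the lower of the two numbers measured so far. Compound 1 `O=C(O)c1cccc(-c2csc(-c3ccccc3F)n2)c1`, on a different core, gives 55200 nM in this assay. Compound 3 `NCc1cccc(-c2cnc(Nc3ccc(F)cc3)o2)c1` is not yet measured; it differs from compound 2 by aminomethyl in place of methylcarbamoyl on an aromatic carbon. For the measured compounds named here, no measured pair shows this change, so the step is taken from the structures alone: an upward step beyond the scatter is expected, as a 4.8-fold higher number from compound 2 to compound 3 (0.68 log units; beyond the scatter). Compound 3 is therefore estimated at 15000 nM in this assay, within a range of 3500 nM to 70000 nM.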

Compound 3, solubility: 50800 nM
Beside the measured number, compound 3's estimate is 3.4-fold (0.53 log units) below it; measured number inside the range.
By their numbers in this assay, from the lowest: compound 2; then compounds 3 and 1 (each within the scatter of the next).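

On the shared core, aminomethyl in place of methylcarbamoyl on this aromatic carbon gives a 16-fold higher number from compound 2 to compound 3 (1.21 log units; beyond the scatter) in this assay, a large step. Among the compounds shown here, this is the only measured pair that differs in one place, so it gives the first direct sign that the read-out is sensitive to the group at this position. Nothing on hand explains the size of this step.

A single pair cannot show whether the step carries over to the core of compound 1. From the compounds shown here alone, how hydroxymethyl or a longer aminoethyl chain would read at this position remains open.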